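This account rests on a few compounds, and the source may have more. Where it says the series, first, only, none or still open, it means among the compounds named here.

Among the compounds with values here, in a functional assay on SW480 cells (Homo sapiens) for antiproliferative activity, read by MTT assay, with a stated time of 48 h (on this read-out higher numbers stand for weaker inhibition and lower numbers for stronger inhibition), compound 2 `CCCCCCCC(CCO)n1cnc2c(OC)ncnc21` gives 23900 nM, the only exact number so far. Compound 3 `CCCCCCCC(CCO)n1cnc2c(NC)ncnc21` differs from it in one place, with methylamino in place of methoxy on an aromatic carbon. Within the data shown here, no measured pair shows this swap alone. Compound 1 `CCCCCC(CCO)n1cnc2c(NC)ncnc21`, which carries methylamino on a different side chain, reaches only a limit of the assay, > 50000 nM, and this is the sole hint available. A small shift toward weaker inhibition in this assay is therefore expected, a 1.3-fold higher number from compound 2 to compound 3 (0.13 log units; within the scatter). For compound 3 the estimated value is 32000 nM, with an expected range from 14000 nM to 70000 nM.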

Compound 3, half-maximal inhibitory concentration: 15300 nM
Compound 3: middle estimate off by 2.1-fold (0.32 log units), on the high side; the range from low to high includes it.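

In this assay, methylamino in place of methoxy on this aromatic carbon gives a 1.6-fold lower number from compound 2 to compound 3 (0.19 log units; within the scatter), so the added hydrogen-bond donor brings no change that can be told from the scatter. The step beyond the scatter lies in the side chain, where ethyl in place of hydrogen on a saturated chain carbon, six bonds along the chain from an aromatic nitrogen, gives an at least 3.2-fold lower number from compound 1 to compound 3 (0.51 log units; beyond the scatter). Compound 1 stands at a limit, so this step has no exact size: the limit of > 50000 nM in this assay, at which 1 of the 3 values shown sits.

Going by these compounds, whether a longer chain would give stronger inhibition remains open. So does how a plain amino group or an ethoxy group would compare on the same aromatic carbon.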